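A few compounds are considered here, and "the series" means these few. Any claim that something is new, unique, unknown or untested is made for them only; others in the source may bear on it.

Three compounds share one core and differ only in the group attached to a sulfonyl sulfur. Compound 1 `CC(C)n1cc(S(=O)(=O)c2ccc(CNC(=O)N3Cc4ccncc4C3)cc2)cn1` gives 20 nM in an assay on isolated protein for inhibition of Nicotinamide phosphoribosyltransferase (Homo sapiens), read by mass spectrometry, with stated times of 15 min and 30 min; a higher number here means a weaker inhibitor, a lower number a stronger inhibitor. Compound 2 `O=C(NCc1ccc(S(=O)(=O)C2CCOCC2)cc1)N1Cc2ccncc2C1` gives 26 nM in this assay, and compound 3 `CN1CCN(S(=O)(=O)c2ccc(CNC(=O)N3Cc4ccncc4C3)cc2)CC1` gives 38 nM. Compound 3 has the highest of the three numbers, but both neighbours sit close to it: a 1.5-fold higher number from compound 2 to compound 3 (0.16 log units; within the scatter) and a 1.9-fold higher number from compound 1 to compound 3 (0.28 log units; within the scatter), so no order among the three can be read from these results.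

Compound 4 `O=C(NCc1ccc(S(=O)(=O)N2CCC(N3CCCC3)CC2)cc1)N1Cc2ccncc2C1` continues the variation at the same sulfonyl sulfur: 4-(pyrrolidin-1-yl)piperidin-1-yl in place of 4-methylpiperazin-1-yl on a sulfonyl sulfur. The exchanges made so far at this position all left the number essentially where it stood: a 1.3-fold higher number from compound 1 to compound 2 (0.11 log units; within the scatter), a 1.9-fold higher number from compound 1 to compound 3 (0.28 log units; within the scatter) and a 1.5-fold higher number from compound 2 to compound 3 (0.16 log units; within the scatter). Within the data shown here, the group entering compound 4 is unlike any tried so far at this position, so the earlier steps are an imperfect guide, yet none of them points to a move in either direction. The expected step is therefore a 1.1-fold lower number from compound 3 to compound 4 (0.04 log units; within the scatter), that is, no change beyond the scatter. The estimate for compound 4 in this assay is 35 nM, with a range from 15 nM to 90 nM.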

Compound 4, half-maximal inhibitory concentration: 7.4 nM
Compound 4: middle estimate off by 4.7-fold (0.67 log units), on the high side, and the stated range ends above it.
By their numbers in this assay, from the lowest: compound 4; then compounds 1, 2 and 3 (each within the scatter of the next).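

At this sulfonyl sulfur, the earlier exchanges stayed within the scatter, but in this assay 4-(pyrrolidin-1-yl)piperidin-1-yl gives a 5.1-fold lower number from compound 3 to compound 4 (0.71 log units; beyond the scatter) and a 3.5-fold lower number from compound 2 to compound 4 (0.55 log units; beyond the scatter) and also a 2.7-fold lower number from compound 1 to compound 4 (0.43 log units; beyond the scatter), all modest but beyond the scatter. The position is therefore not indifferent to what sits on it, and compound 4 is the strongest inhibitor of the four. Set against the 4-methylpiperazin-1-yl group of compound 3, the entering group has 11 heavy atoms rather than 7 and two rings rather than one, while its counts of hydrogen-bond donors and acceptors are unchanged, and nothing at hand explains why the number falls.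

Among these compounds, with only one group of this type among the compounds, the change cannot yet be assigned to a particular part of it. A plain piperidin-1-yl group or a 4-(dimethylamino)piperidin-1-yl group on the same sulfonyl sulfur would show whether the lower number depends on the outer pyrrolidine ring, on the second ring nitrogen, or on neither.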